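The source may hold more compounds than are shown below. What is called first, only, known or untested is meant among the compounds shown, and "the series" means these compounds.

Working notes on the series. In a functional assay on SF-268 cells (Homo sapiens) for cytotoxicity, read by sulforhodamine B assay, with a stated time of 48 h (a lower number here means that less compound is tolerated, a higher number that more compound is tolerated), compound 1, `ClCc1cccc(Cn2cnc3c(Cl)ncnc32)c1`, reports only a limit of the assay, > 100000 nM. Compound 2, `ClCc1cccc(Cn2cnc3c(Cl)nc(Cl)nc32)c1`, gives 70800 nM in this assay. The change between them is chloro in place of hydrogen on an aromatic carbon, and it made the step of an at least 1.4-fold lower number from compound 1 to compound 2 (0.14 log units; that floor lies within the scatter); how far the step really reaches is bounded because of the limit of > 100000 nM in this assay, at which 2 of the 3 values shown sit. Compound 3, `ClCc1ccccc1Cn1cnc2ncnc(Cl)c21`, also reports only a limit in this assay, > 100000 nM. The difference between the core of compound 1 and the core of compound 3 is not broken down here. Compound 4, `ClCc1ccccc1Cn1cnc2nc(Cl)nc(Cl)c21`, remains to be measured in this assay and differs from compound 3 by chloro in place of hydrogen on an aromatic carbon, the same change as that from compound 1 to compound 2, at a place described in the same words; it is the only other occurrence of the change among the compounds shown. The expectation for compound 4 rests on the step of an at least 1.4-fold lower number from compound 1 to compound 2 (0.14 log units; that floor lies within the scatter). For compound 4 the step of an at least 1.2-fold lower number from compound 3 to compound 4 (0.09 log units; that floor lies within the scatter) is expected. Compound 4 is estimated at 80000 nM, with a range from 40000 nM to 200000 nM, and a real chance that only a limit is reported again.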

Compound 4, concentration lethal to 50% of the cells: > 100000 nM
Compound 4: a limit, no number (the forecaster's own chance of this, stated with the estimate: 40%); at least 1.2-fold (0.09 log units) between middle value and limit.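

Compound 3 and compound 4 each report only a limit in this assay, so no step from compound 3 to compound 4 can be read: the limit of > 100000 nM in this assay, at which 3 of the 4 values shown sit.

The compounds shown leave open whether chloro in place of hydrogen on an aromatic carbon changes the number at all on the core of compound 3.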